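The compounds below may be only part of what the source reports. "The series", "measured", "known", "first", "only" and "open" are said of these compounds alone.

Compound 3 `COCCOc1ccc2c(c1)CCc1c-2c2c(c3c4ccccc4n(CCO)c13)CNC2=O` gives 40% in an assay on isolated protein for inhibition of mitogen-activated protein kinase kinase kinase 11 (Homo sapiens), tested at 1 uM (on this read-out higher numbers stand for more inhibition at the one concentration tested (going by the name of the read-out) and lower numbers for less inhibition), the second highest of the three numbers: it stands near compound 2 `O=C1NCc2c1c1c(c3c2c2ccccc2n3CCO)CCc2cc(OCCO)ccc2-1`, which gives 46%, the two lying within the scatter, and far from compound 1 `O=C1NCc2c1c1c(c3c2c2ccccc2n3CCO)CCc2cc(OC3CCCCC3)ccc2-1`, which gives 4%. Compound 4 `O=C1NCc2c1c1c(c3c2c2ccccc2n3CCO)CCc2cc(OC3CCCC3)ccc2-1` has not yet been measured; it differs from compound 3 by cyclopentyl in place of 2-methoxyethyl on an oxygen on an aromatic ring. The step that bears on this is the one that brought the 2-methoxyethyl in, a number 36 percentage points higher from compound 1 to compound 3 (beyond the scatter), alongside a number 42 percentage points higher from compound 1 to compound 2 (beyond the scatter); since a cyclopentyl resembles the cyclohexyl of compound 1 more than either chain, a fall back toward compound 1 is expected. The expected step is a number 28 percentage points lower from compound 3 to compound 4 (beyond the scatter). For compound 4 the estimate is 12%, within 0% to 30%.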

Compound 4, a percentage reported as inhibition, at one concentration (the size of the read-out at that concentration, not a potency): 32%
The estimate for compound 4 lay 20 percentage points below the measured number; the whole stated range lies below it.
By their numbers in this assay, from the lowest: compound 1; then compounds 4, 3 and 2 (each within the scatter of the next, the first and the last beyond it).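

In this assay, a carbon-only ring on this oxygen does not by itself bring the number down, since the cyclopentyl and cyclohexyl compounds differ by a modest step (a number 28 percentage points higher from compound 1 to compound 4 (beyond the scatter)). Cyclopentyl, with no hydrogen-bond acceptor, stands level with 2-methoxyethyl (a number 8 percentage points lower from compound 3 to compound 4 (within the scatter)), yet it falls modestly short of 2-hydroxyethyl (a number 14 percentage points lower from compound 2 to compound 4 (beyond the scatter)). No measurement shown accounts for these differences. The compounds shown leave open how a smaller ring such as cyclobutyl would compare with cyclopentyl, and how an amine or a carboxylic acid at the end of a longer chain on this oxygen would compare with 2-hydroxyethyl.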